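Swapping the Pyridine Amide Cap in a Triazole Series

The source may hold more compounds than are shown below. What is called first, only, known or untested is meant among the compounds shown, and "the series" means these compounds.

Compound 2 `COc1ccc(Cn2c(CCc3c[nH]c4ccccc34)nnc2[C@H](NC(=O)c2ccccn2)c2c[nH]c3ccccc23)cc1` gives 102 nM in a functional assay on CHO cells for antagonist activity at growth hormone secretagogue receptor type 1 (Homo sapiens) (on this read-out higher numbers stand for weaker inhibition and lower numbers for stronger inhibition), and holds the second highest of the three measured numbers. Compound 1 `CCc1ccc(-n2c(CCc3c[nH]c4ccccc34)nnc2[C@H](NC(=O)c2ccccn2)c2c[nH]c3ccccc23)cc1` gives 129 nM in this assay, and the step of a 1.3-fold lower number from compound 1 to compound 2 (0.10 log units; within the scatter) stays within the scatter. Compound 3 `COc1ccc(Cn2c(CCc3ccccc3)nnc2[C@H](NC(=O)c2ccccn2)c2c[nH]c3ccccc23)cc1` gives 12 nM, and the step of an 8.5-fold lower number from compound 2 to compound 3 (0.93 log units; beyond the scatter) goes beyond the scatter. Compound 4 `COc1ccc(Cn2c(CCc3c[nH]c4ccccc34)nnc2[C@H](NC(=O)Cc2ccncc2)c2c[nH]c3ccccc23)cc1` differs from compound 2 in one place: (pyridin-4-yl)methyl in place of pyridin-2-yl on a carbonyl carbon. Neither measured step touches this carbonyl group: the step from compound 1 to compound 2 alters the group on the aromatic nitrogen, and the step from compound 2 to compound 3 alters the chain. With nothing bearing on this change, compound 4 is expected to land near compound 2. The step of a 1.5-fold higher number from compound 2 to compound 4 (0.17 log units; within the scatter) is expected to stay within the scatter. The estimate for compound 4 in this assay is 150 nM, with a range from 40 nM to 600 nM.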

Compound 4, antagonist equilibrium constant: 10 nM
The estimate for compound 4 lay 15-fold (1.18 log units) above the measured number, and the stated range ends above it.
By their numbers in this assay, from the lowest: compounds 4 and 3 (each within the scatter of the next); then compounds 2 and 1 (each within the scatter of the next).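

Changing the group on the carbonyl carbon gives a 10-fold lower number from compound 2 to compound 4 (1.01 log units; beyond the scatter) in this assay, so this position can strongly affect the read-out, which the earlier changes to the group on the aromatic nitrogen and the chain could not show. The evidence available gives no explanation for this result.

The change alters both the pyridine attachment and the link to the carbonyl carbon, and the compounds shown do not separate these two differences. Pyridin-4-yl directly on the carbonyl carbon, or (pyridin-2-yl)methyl there, remains open.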